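Aminothiazole series: cytotoxicity in liver-cell culture

The source may report more compounds than this note shows. Statements on the series, on what has been measured and on what is new or still open speak of the compounds shown alone.

Measured compounds:
- compound 1 `O=C(Nc1ncc(Cc2ccc(F)cc2)s1)c1ccc(Cl)cc1Cl`, > 50000 nM
- compound 2 `O=C(Nc1ncc(Cc2ccc(Br)cc2)s1)c1cccs1`, > 50000 nM
- compound 3 `COC(=O)CCCCNc1ncc(C(Oc2ccc3cc(Br)ccc3c2)c2ccc(Cl)cc2)s1`, "not toxic" (no number reported)

In an ADME assay on HepG2 2.2.15 cells (Homo sapiens) for cytotoxicity (on this read-out lower numbers stand for higher toxicity in this test and higher numbers for lower toxicity in this test), compound 1 gives > 50000 nM, which is a limit of the assay and not a number. Compound 2 likewise gives > 50000 nM in this assay, again a limit. For compound 3 no single number is given in this assay; it is reported as "not toxic" (no number reported), and the two other values shown sit at the limit of > 50000 nM in this assay, at which 2 of the 3 values shown sit. Compound 4 `CCc1ccc(S(=O)(=O)Nc2ncc(C(Oc3ccc4cc(Br)ccc4c3)c3ccc(Cl)cc3)s2)cc1` differs from compound 3 by (4-ethylphenyl)sulfonyl in place of 4-(methoxycarbonyl)butyl on a nitrogen on an aromatic ring. Among the compounds with values here, no step between measured compounds is available, so no direction beyond the scatter is expected in this assay. For compound 4 the value in this assay is estimated at 50000 nM, with a range from 20000 nM to 100000 nM, most likely reported as a limit.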

Compound 4, half-maximal cytotoxic concentration: > 50000 nM
Compound 4 ended at the assay's limit (the forecaster's own chance of this, stated with the estimate: 70%); the middle value lies on the limit itself.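

Compound 3 carries no number and compound 4 gives only a limit, so no step can be read between them: the limit of > 50000 nM in this assay, at which 3 of the 4 values shown sit.

The compounds shown leave open at what concentration any of them would become toxic.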